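Side-chain saturation in a series with no measurable activity

This account rests on a few compounds, and the source may have more. Where it says the series, first, only, none or still open, it means among the compounds named here.

The series is characterised in a functional assay on MDA-MB-231 cells (Homo sapiens) for antiproliferative activity, read by MTT assay; a higher number here means a weaker inhibitor, a lower number a stronger inhibitor. Compound 1 `CCCC/C=C\CCCCCCCCCc1cc(=O)c2c(O)c(C)c(OCOC)cc2o1` carries a cis-olefinic side chain on the core of compound 1. In this assay compound 1 gives only a limit, > 87000 nM. Compound 2 `CCCCCCCCCCCCCCCc1cc(=O)c2c(O)c(C)c(OCOC)cc2o1` is its saturated counterpart, the change being (hexyl in place of hex-1-en-1-yl on a saturated chain carbon, nine bonds along the chain from an aromatic carbon). In this assay compound 2 likewise gives only a limit, > 87000 nM. The step that the two limits leave unreadable from compound 1 to compound 2 therefore cannot be sized, because of the limit of > 87000 nM in this assay, at which 3 of the 3 values shown sit.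

Compound 3 `CCCC/C=C\CCCCCCCCCc1cc(=O)c2c(O)c(C)c(O)c(C)c2o1` sits on a second core; how the core of compound 3 differs from the core of compound 1 is not broken down here. In this assay compound 3 also gives only a limit, > 87000 nM.

Compound 4 `CCCCCCCCCCCCCCCc1cc(=O)c2c(O)c(C)c(O)c(C)c2o1` has not yet been measured. It differs from compound 3 by hexyl in place of hex-1-en-1-yl on a saturated chain carbon, nine bonds along the chain from an aromatic carbon, the same change as that made from compound 1 to compound 2. Since that earlier pair stayed at the limit, compound 4 is expected to behave alike, with an estimated value of 87000 nM, between 40000 nM and 200000 nM. The expected step is a number no higher from compound 3 to compound 4 (the limit leaves the size open), resting on the unreadable step that the two limits leave unreadable from compound 1 to compound 2. Most likely compound 4 will again return only a limit.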

Compound 4, half-maximal inhibitory concentration: > 87000 nM
Compound 4 gave a limit, no number; the forecaster's own chance of this, stated with the estimate: 85%; the middle value sits exactly at the limit.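

Compound 4 adds no readable step to the series: the change from compound 3 to compound 4 cannot be sized, because both values are limits: the limit of > 87000 nM in this assay, at which 4 of the 4 values shown sit.

The compounds shown leave open whether hexyl and hex-1-en-1-yl differ at all in this assay on either core, and what structure would give a measurable value there.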